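Lactam ring variation on the fused core: clearance notes

The compounds below may be only part of what the source reports. "The series", "measured", "known", "first", "only" and "open" are said of these compounds alone.

Values in an ADME assay on microsomes from liver (Rattus norvegicus) for metabolic stability, read by LC-MS, using NADPH, with a stated time of 30 min, tested at 1 uM; on this read-out lower numbers stand for slow clearance and higher numbers for fast clearance:
compound 1 `CC(C)c1noc(N2CCC(Oc3cc(N4CCc5cc(N6CCCCC6=O)ccc54)ncn3)CC2)n1`: 13 mL.min-1.g-1
compound 2 `CC(C)c1noc(N2CCC(Oc3cc(N4CCc5cc(C6CCCCC6=O)ccc54)ncn3)CC2)n1`: 141 mL.min-1.g-1
compound 3 `CC(C)c1noc(N2CCC(Oc3cc(N4CCc5cc(N6CC(O)CCC6=O)ccc54)ncn3)CC2)n1`: 7 mL.min-1.g-1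

Compound 3 gives the lowest number of the three; compound 1 lies within the scatter of it, whereas compound 2 is far beyond it, as a 20-fold lower number from compound 2 to compound 3 (1.30 log units; beyond the scatter) shows. Compound 4 `CC(C)c1noc(N2CCC(Oc3cc(N4CCc5cc(N6CCOCC6=O)ccc54)ncn3)CC2)n1` differs from compound 3 in one place: 3-oxomorpholin-4-yl in place of 5-hydroxy-2-oxopiperidin-1-yl on an aromatic carbon. Among the compounds with values here, two measured steps bear on this. an 11-fold higher number from compound 1 to compound 2 (1.04 log units; beyond the scatter) shows that 2-oxocyclohexyl in place of 2-oxopiperidin-1-yl moved the read-out strongly, while a 1.9-fold lower number from compound 1 to compound 3 (0.27 log units; within the scatter) shows that the hydroxy group alone did little. Compound 4 keeps a ring of the 2-oxopiperidin-1-yl kind, only losing the hydrogen-bond donor and gaining a second hetero atom in the ring, so the expected step is a 1.4-fold higher number from compound 3 to compound 4 (0.15 log units; within the scatter), small and toward compound 1. Compound 4 is therefore estimated at 10 mL.min-1.g-1, range 4 mL.min-1.g-1 to 25 mL.min-1.g-1.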

Compound 4, intrinsic clearance in microsomes in the Rattus norvegicus assay: 46 mL.min-1.g-1
Estimate against measurement, compound 4: 4.6-fold (0.66 log units) below; the measured number lies above the stated range.
By their numbers in the Rattus norvegicus assay, from the lowest: compounds 3 and 1 (each within the scatter of the next); then compound 4; then compound 2.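

In the Rattus norvegicus assay, a second hetero atom in the six-membered non-aromatic ring is not a silent change at this aromatic carbon: a 3.5-fold higher number from compound 1 to compound 4 (0.55 log units; beyond the scatter), a 6.6-fold higher number from compound 3 to compound 4 (0.82 log units; beyond the scatter), yet a 3.1-fold lower number from compound 2 to compound 4 (0.49 log units; beyond the scatter). In a physicochemical assay for lipophilicity, measured as octanol-water partition, at pH 7.4 (a higher number here means a more lipophilic compound, a lower number a more polar compound), compound 3 gives 2.6 and compound 4 gives 3.1. The rise in clearance from compound 3 may be partly due to higher lipophilicity, though this rests on one pair: the measured distribution coefficient of compound 3, 2.6, and of compound 4, 3.1, a number 0.50 log units higher (beyond the scatter)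

Still open, as far as these compounds go, is where an amine or a carboxylic acid on this ring would fall against compound 3.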